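Replacing 5-chloropyridin-2-yl with 4-chlorophenyl on the sulfonyl sulfur

The compounds below may be only part of what the source reports. "The series", "measured", "known", "first", "only" and "open" are said of these compounds alone.

Compound 3 (`N#Cc1ccc(O[C@H]2CN(S(=O)(=O)c3ccc(Cl)cn3)C[C@@]2(O)CO)cc1F`) gives 170 mL/min/kg in an ADME assay on the whole organism (Rattus norvegicus, strain Sprague-Dawley) for pharmacokinetics, read by LC-MS, with a stated time of 30 min, at a dose of 1 mg/kg by the intravenous route (on this read-out lower numbers stand for slow clearance and higher numbers for fast clearance), and compound 2 (`N#Cc1ccc(O[C@H]2CN(S(=O)(=O)c3ccccc3C#N)C[C@@]2(O)CO)cc1F`) gives 200 mL/min/kg, the two lying within the scatter of each other at the low end of this small series. Compound 1 (`N#Cc1ccc(O[C@H]2CN(S(=O)(=O)c3ccc(C(F)(F)F)cc3)C[C@@]2(O)CO)cc1F`) stands well apart at 1500 mL/min/kg.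

Compound 4 (`N#Cc1ccc(O[C@H]2CN(S(=O)(=O)c3ccc(Cl)cc3)C[C@@]2(O)CO)cc1F`) differs from compound 3 in one place, with 4-chlorophenyl in place of 5-chloropyridin-2-yl on a sulfonyl sulfur. Going by the values given here, three measured steps bear on this change. Two were modest, an 8.8-fold lower number from compound 1 to compound 3 (0.95 log units; beyond the scatter) and a 7.5-fold lower number from compound 1 to compound 2 (0.88 log units; beyond the scatter), while a 1.2-fold lower number from compound 2 to compound 3 (0.07 log units; within the scatter) stayed within the scatter. Compound 4 shares a carbon-only aromatic ring with compound 1, which suggests a rise, but compound 2 goes against that reading with its own carbon-only ring at 200 mL/min/kg. Among the compounds with values here, no measured pair isolates this exchange, so the expectation remains loose.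

The expected change is a moderate rise, a 2.9-fold higher number from compound 3 to compound 4 (0.47 log units; beyond the scatter). Compound 4 is estimated at 500 mL/min/kg, with an expected range of 180 mL/min/kg to 1400 mL/min/kg.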

Compound 4, clearance: 1540 mL/min/kg
The estimate for compound 4 lay 3.1-fold (0.49 log units) below the measured number; the measured number lies above the stated range.
By their numbers in this assay, from the lowest: compounds 3 and 2 (each within the scatter of the next); then compounds 1 and 4 (each within the scatter of the next).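

In this assay, going by these compounds alone, 4-chlorophenyl in place of 5-chloropyridin-2-yl brings a 9.1-fold higher number from compound 3 to compound 4 (0.96 log units; beyond the scatter) and gives the first direct reading of this exchange on the sulfonyl sulfur, where the two groups differ only by a ring nitrogen against a ring carbon. Chloro in place of trifluoromethyl on an aromatic carbon gives a 1.0-fold higher number from compound 1 to compound 4 (0.01 log units; within the scatter) and so leaves the number unmoved, yet a carbon-only ring does not go with the high number in every case, as 4-chlorophenyl in place of 2-cyanophenyl brings a 7.7-fold higher number from compound 2 to compound 4 (0.89 log units; beyond the scatter) and the 2-cyanophenyl group stays at the low end. Nothing given here explains these steps.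

From the compounds shown here alone, whether a ring nitrogen would bring a similar drop alongside a trifluoromethyl or a nitrile remains open. Also open, going by these compounds, is how an amine or a carboxylic acid on the aromatic ring would read in this assay and whether either would stay at the low end.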